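Terminal urea aryl swap on the shared core

A few compounds are considered here, and "the series" means these few. Any claim that something is new, unique, unknown or untested is made for them only; others in the source may bear on it.

Compound 1 `COc1ccccc1NC(=O)Nc1cccc(CNc2ncnc3ccccc23)c1` carries a methoxy on the terminal aromatic ring, and in a functional assay on HepG2 cells (Homo sapiens) for antiproliferative activity, read by MTT assay (a higher number here means a weaker inhibitor, a lower number a stronger inhibitor), compound 1 gives 17500 nM. Compound 2 `O=C(Nc1cccc(CNc2ncnc3ccccc23)c1)Nc1ccccc1Cl` has chloro in place of that methoxy; in this assay compound 2 gives > 50000 nM, which is a limit of the assay and not a number. The step of an at least 2.8-fold higher number from compound 1 to compound 2 (0.45 log units; beyond the scatter) is thus bounded only from below, fixed by the limit of > 50000 nM in this assay, at which 1 of the 2 values shown sits. On the numbers shown compound 2 stands at the upper edge of what this assay reports and is the weaker of the two.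

Compound 3 `O=C(Nc1ccc([N+](=O)[O-])cc1)Nc1cccc(CNc2ncnc3ccccc23)c1` differs from compound 2 by 4-nitrophenyl in place of 2-chlorophenyl on an amide-type nitrogen. No measured step touches the same place in the same way: the only step shown, from compound 1 to compound 2, exchanges one substituent on an aromatic carbon of the same ring and carries only a lower bound, so it gives no direction for the nitro ring. The expected step of an at least 1.2-fold lower number from compound 2 to compound 3 (0.09 log units; that floor lies within the scatter) is set near zero, with wide uncertainty and a real chance that only a limit is returned again. Compound 3 is estimated at 40000 nM, within 15000 nM to 120000 nM.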

Compound 3, half-maximal inhibitory concentration: 24600 nM
Beside the measured number, compound 3's estimate is 1.6-fold (0.21 log units) above it; the measured number falls inside the stated range.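

Exchanging 2-methoxyphenyl for 4-nitrophenyl on the amide-type nitrogen gives a 1.4-fold higher number from compound 1 to compound 3 (0.15 log units; within the scatter), so in this assay these two terminal rings cannot be told apart, and this place accepts a second, quite different aryl group while still returning a number. Exchanging 2-chlorophenyl for 4-nitrophenyl at the same place gives an at least 2.0-fold lower number from compound 2 to compound 3 (0.30 log units; that floor lies within the scatter), a floor that does not by itself establish a difference, although the true gap may be larger. Compound 2 remains a limit and not a number, and the size of both of its steps stays bounded on one side only: the limit of > 50000 nM in this assay, at which 1 of the 3 values shown sits.

The 2-methoxyphenyl and 4-nitrophenyl rings differ both in the substituent and in the number it carries in the group's name, so the compounds shown do not separate the effect of the group from that of its location on the ring. Going by these compounds, how an unsubstituted phenyl ring, or a terminal ring bearing an amine or a carboxylic acid, would read in this assay also remains open.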